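A few compounds are considered here, and "the series" means these few. Any claim that something is new, unique, unknown or untested is made for them only; others in the source may bear on it.

In a functional assay on B16-F10 cells (Mus musculus) for inhibition, read by MTT assay, with a stated time of 72 h (on this read-out lower numbers stand for stronger inhibition and higher numbers for weaker inhibition), compound 1 `N#Cc1c(Nc2cccc(C(F)(F)F)c2)nc(SCc2cn(Cc3ccccc3Cl)nn2)nc1-c1ccccc1` gives 3710 nM, compound 2 `N#Cc1c(Nc2ccccc2Cl)nc(SCc2cn(Cc3ccccc3Cl)nn2)nc1-c1ccccc1` gives 8350 nM, and compound 3 `COc1ccccc1Nc1nc(SCc2cn(Cc3ccccc3Cl)nn2)nc(-c2ccccc2)c1C#N` gives 7860 nM. Compound 3 thus stands second highest of the three numbers: its gap to compound 2 lies within the usual scatter, whereas the step of a 2.1-fold higher number from compound 1 to compound 3 (0.33 log units; beyond the scatter) lies beyond it.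

Compound 4 `N#Cc1c(Nc2ccccc2F)nc(SCc2cn(Cc3ccccc3Cl)nn2)nc1-c1ccccc1` differs from compound 3 by fluoro in place of methoxy on an aromatic carbon. Going by the values given here, the one measured step at the same place, a 1.1-fold lower number from compound 2 to compound 3 (0.03 log units; within the scatter), stayed within the scatter; the step of a 2.3-fold higher number from compound 1 to compound 2 (0.35 log units; beyond the scatter) concerned a different change and was only modest. Compound 4 is therefore expected to sit close to compound 3, with a 1.0-fold lower number from compound 3 to compound 4 (0.02 log units; within the scatter) inside the scatter. The estimate for compound 4 in this assay is 7500 nM, ranging from 3500 nM to 16000 nM.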

Compound 4, half-maximal inhibitory concentration: 5230 nM
The estimate for compound 4 lay 1.4-fold (0.16 log units) above the measured number; low and high end bracket the measured number.
By their numbers in this assay, from the lowest: compounds 1, 4, 3 and 2 (each within the scatter of the next, the first and the last beyond it).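

In this assay, fluoro on this aromatic carbon cannot be told apart from methoxy (a 1.5-fold lower number from compound 3 to compound 4 (0.18 log units; within the scatter)) or from chloro (a 1.6-fold lower number from compound 2 to compound 4 (0.20 log units; within the scatter)), so all three groups at this place lie within the scatter of one another. Unlike the 2-chlorophenyl and 2-methoxyphenyl groups, 2-fluorophenyl also stays within the scatter of 3-(trifluoromethyl)phenyl (a 1.4-fold higher number from compound 1 to compound 4 (0.15 log units; within the scatter)). Nothing available explains these small steps. Going by these compounds, whether an amine or a carboxylic acid on this carbon would give a step beyond the scatter remains open.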